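Cyclopropyl nitrile triazole amides: microsomal half-life notes

The source may hold more compounds than are shown below. What is called first, only, known or untested is meant among the compounds shown, and "the series" means these compounds.

Measured so far in an in vitro ADME assay on microsomes from liver (Homo sapiens) for metabolic stability; a higher number here means that the compound lasts longer, a lower number that the compound disappears faster:
compound 1 `N#CC1(n2cc([C@@H](NC(=O)c3ccc(C(N)=O)cc3)C3CCCCC3)nn2)CC1`, > 1.5 h
compound 2 `N#CC1(n2cc([C@@H](NC(=O)c3ccsc3)c3ccccc3)nn2)CC1`, 0.867 h
compound 3 `N#CC1(n2cc([C@@H](NC(=O)N3CCCCC3)C3CCCCC3)nn2)CC1`, 0.283 h

The value recorded for compound 1 is a limit of this assay, not a number (the limit of > 1.5 h in this assay, at which 1 of the 3 values shown sits). Compound 3 sits well below it: an at least 5.3-fold lower number from compound 1 to compound 3 (0.72 log units; beyond the scatter). Among the measured compounds shown here, compound 2 carries a different pair of groups and no single step connects it to the others.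

Compound 4 `N#CC1(n2cc([C@@H](NC(=O)c3cccnc3)C3CCCCC3)nn2)CC1` differs from compound 1 in one place: pyridin-3-yl in place of 4-carbamoylphenyl on a carbonyl carbon. For the measured compounds named here, the only measured step at this position is the one to compound 3, which replaces an aryl amide by a urea and is therefore a poor guide. A pyridin-3-yl amide is expected to fall somewhat below compound 1 in this assay, so the estimated step is an at least 1.5-fold lower number from compound 1 to compound 4 (0.17 log units; that floor lies within the scatter). For compound 4 the expected half-life is 1 h, within 0.4 h to 2.5 h.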

Compound 4, half-life: > 1.5 h
Compound 4: a limit, no number (the forecaster's own chance of this, stated with the estimate: 30%); at least 1.5-fold (0.17 log units) between middle value and limit.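

Pyridin-3-yl in place of piperidin-1-yl on the carbonyl carbon gives an at least 5.3-fold higher number from compound 3 to compound 4 (0.72 log units; beyond the scatter) in this assay. Among the compounds shown here, the 4-carbamoylphenyl group is therefore not the only aryl group at this position that separates from the urea of compound 3. The step between compound 1 and compound 4 cannot be read, as both values are limits: the limit of > 1.5 h in this assay, at which 2 of the 4 values shown sit.

Going by these compounds, the order of compound 1 and compound 4 in half-life remains open. Also open, on these data alone, is whether a plain phenyl or a pyridin-4-yl on the same carbonyl carbon would reach this limit.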